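This account rests on a few compounds, and the source may have more. Where it says the series, first, only, none or still open, it means among the compounds named here.

Three compounds share one core and differ only in what hangs from the nitrogen on the aromatic ring. Compound 1 `CCCC(CN(C)C)Nc1nc(C)nc2c1nnn2-c1ccc(C(C)C)cc1Br` gives 38.7 nM in an in vitro assay on 293-EBNA cells for binding affinity to corticotropin-releasing factor receptor 1 (Homo sapiens); a lower number here means a stronger inhibitor, a higher number a weaker inhibitor. Compound 2 `CCCCNc1nc(C)nc2c1nnn2-c1ccc(C(C)C)cc1Br` gives 69.6 nM in this assay, and the step of a 1.8-fold higher number from compound 1 to compound 2 (0.25 log units; within the scatter) stays within the scatter. Compound 3 `CCCCC(CCCC)Nc1nc(C)nc2c1nnn2-c1ccc(C(C)C)cc1Br` gives 4.5 nM in this assay, the lowest of the three numbers, reached by a 15-fold lower number from compound 2 to compound 3 (1.19 log units; beyond the scatter) and by an 8.6-fold lower number from compound 1 to compound 3 (0.93 log units; beyond the scatter).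

Compound 4 `CCC(CC)Oc1nc(C)nc2c1nnn2-c1ccc(C(C)C)cc1Br` has not yet been measured. Its change from compound 3 is a group of 6 heavy atoms (5 carbon, 1 oxygen; no ring) in place of a group of 10 heavy atoms (9 carbon, 1 nitrogen; no ring), on an aromatic carbon. Among the compounds with values here, no measured step covers the exchange of a nitrogen link for an oxygen link, so that part is open. The steps that do bear on it concern the size and branching of the chain at this position: a 15-fold lower number from compound 2 to compound 3 (1.19 log units; beyond the scatter) shows that a longer, branched chain brought a large gain, and an 8.6-fold lower number from compound 1 to compound 3 (0.93 log units; beyond the scatter) a modest one. Compound 4 keeps a branched chain but a shorter one, and gives up the hydrogen-bond donor. Compound 4 is therefore expected to lose some ground against compound 3, with an estimated 3.3-fold higher number from compound 3 to compound 4 (0.52 log units; beyond the scatter). Compound 4 is expected to give 15 nM in this assay, within a range from 4 nM to 60 nM.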

Compound 4, inhibition constant: 1.9 nM
The estimate for compound 4 lay 7.9-fold (0.90 log units) above the measured number; measured number outside the range, below it.
By their numbers in this assay, from the lowest: compound 4; then compound 3; then compounds 1 and 2 (each within the scatter of the next).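

In this assay, replacing the large nitrogen-linked group of compound 3 with (pentan-3-yl)oxy gives a 2.4-fold lower number from compound 3 to compound 4 (0.37 log units; beyond the scatter), so at this aromatic carbon neither the hydrogen-bond donor of the nitrogen link nor a group of 10 heavy atoms is needed for a low number, as a group of 6 heavy atoms with no donor does better. The earlier compounds shown here showed only that, among nitrogen-linked groups, 1-butylpentyl gave a lower number than the butyl of compound 2 or the group of compound 1, whereas the oxygen-linked group now reaches further with less bulk, with a 37-fold lower number from compound 2 to compound 4 (1.56 log units; beyond the scatter) and a 20-fold lower number from compound 1 to compound 4 (1.31 log units; beyond the scatter). Nothing given here explains why this exchange lowers the number.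

The link and the chain change together in this step, so the share of each cannot be separated; the (pentan-3-yl)amino group on the same core would test the link alone, and a 1-butylpentyloxy group would test the chain on an oxygen link. From the compounds shown here alone, how far the oxygen link tolerates other groups, such as a shorter chain, a ring or a sulfur link in its place, also remains open.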